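The source may report more compounds than this note shows. Statements on the series, on what has been measured and on what is new or still open speak of the compounds shown alone.

Measured compounds in an assay on HEK293 cells for agonist activity at Bile acid receptor (Homo sapiens), read by a luciferase reporter; on this read-out lower numbers stand for smaller maximal responses and higher numbers for larger maximal responses:
- compound 1 `CC(C)OC(=O)C1CN(C(=O)c2ccc(F)cc2)CC(C)(C)c2cc(C#N)[nH]c21`: 85%
- compound 2 `CC(C)OC(=O)C1=CN(C(=O)c2cccc(C(F)(F)F)c2)CC(C)(C)c2cc(C#N)[nH]c21`: 94%
- compound 3 `CC(C)OC(=O)C1=CN(C(=O)c2cccs2)CC(C)(C)c2cc(C#N)[nH]c21`: 114%

Compound 1 has the lowest of the three maximal responses. Its nearest neighbour is compound 2, whose value lies within the usual scatter of compound 1, so no order between these two can be claimed. Compound 3 lies furthest away, beyond the scatter. Among the compounds with values here, the one step between measured compounds that differ in a single place is a number 20 percentage points higher from compound 2 to compound 3 (beyond the scatter), in which one six-membered aromatic ring of carbon only gives way to a different aromatic ring on the carbonyl carbon.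

Compound 4 `CC(C)OC(=O)C1CN(C(=O)C2CCCCC2)CC(C)(C)c2cc(C#N)[nH]c21` differs from compound 1 in one place: cyclohexyl in place of 4-fluorophenyl on a carbonyl carbon. Here an aromatic ring leaves and a non-aromatic ring enters, a kind of change that no measured step covers directly. The step from compound 2 to compound 3 was modest even for a swap between two aromatic rings, and nothing measured shows a non-aromatic ring at this position. The expectation for compound 4 is therefore a change of about no change at the digits printed from compound 1 to compound 4 (within the scatter), not clearly beyond the scatter. Compound 4 is estimated to give 85%, with a range from 65% to 105%.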

Compound 4, largest response reached (reported as efficacy), in percent of the reference or control that the assay uses: 127%
Compound 4: middle estimate off by 42 percentage points, on the low side; measured number outside the range, above it.
By their numbers in this assay, from the lowest: compounds 1 and 2 (each within the scatter of the next); then compound 3; then compound 4.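

In this assay, the position on the carbonyl carbon does not need an aromatic ring for a high maximal response: cyclohexyl in place of 4-fluorophenyl gives a number 42 percentage points higher from compound 1 to compound 4 (beyond the scatter). The earlier step exchanged one aromatic ring for another, whereas this one shows that a non-aromatic ring of carbon only can take this place and give a larger response than the 4-fluorophenyl group in compound 1. Nothing available explains why the response changes in this way.

Going by these compounds, it remains open whether this result is specific to cyclohexyl or would also hold for a smaller ring such as cyclopentyl, an open chain such as butyl, or a cyclohexyl ring carrying an amine. On these data alone, it is also open whether cyclohexyl would give a similar result on the core of compound 3.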